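This account rests on a few compounds, and the source may have more. Where it says the series, first, only, none or still open, it means among the compounds named here.

Three compounds share one core and differ only in the ring on the sulfonamide nitrogen. Compound 1 `O=C1NCCN1c1ccc(S(=O)(=O)Nc2cccc(Br)c2)cc1` gives 77 nM in a functional assay on HT-29 cells (Homo sapiens) for antiproliferative activity, read by sulforhodamine B assay, with a stated time of 48 h; a lower number here means a stronger inhibitor, a higher number a weaker inhibitor. Compound 2 `CCc1ccc(NS(=O)(=O)c2ccc(N3CCNC3=O)cc2)cc1` gives 660 nM, the highest number of the three. Compound 3 `O=C1NCCN1c1ccc(S(=O)(=O)Nc2ccc(F)c(F)c2)cc1` gives 350 nM. The measured steps are an 8.6-fold higher number from compound 1 to compound 2 (0.93 log units; beyond the scatter) and a 4.5-fold higher number from compound 1 to compound 3 (0.66 log units; beyond the scatter), both modest, while a 1.9-fold lower number from compound 2 to compound 3 (0.28 log units; within the scatter) lies within the scatter. Compound 4 `O=C1NCCN1c1ccc(S(=O)(=O)Nc2ccc(C3CCCCC3)cc2)cc1` differs from compound 2 by cyclohexyl in place of ethyl on an aromatic carbon. Among the compounds with values here, no measured step alters the ethyl group itself; each exchanges the whole ring pattern, so the guidance is indirect and a change beyond the scatter is not clearly predicted. The expected step is a 1.3-fold lower number from compound 2 to compound 4 (0.12 log units; within the scatter). Compound 4 is estimated at 500 nM, with a range from 150 nM to 1800 nM.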

Compound 4, half-maximal inhibitory concentration: > 1000 nM
Compound 4: a limit, no number; the forecaster's own chance of this, stated with the estimate: 5%; at least 2.0-fold (0.30 log units) between middle value and limit.
By their numbers in this assay, from the lowest: compound 1; then compounds 3 and 2 (each within the scatter of the next). At a limit, above all of these: compound 4.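

Compound 4 carries a limit of the assay, not a number: the limit of > 1000 nM in this assay, at which 1 of the 4 values shown sits.

Cyclohexyl in place of ethyl gives an at least 1.5-fold higher number from compound 2 to compound 4 (0.18 log units; that floor lies within the scatter), so the true size of this step remains unknown. Still, this is the only step shown that alters the ethyl group itself, and it shows that cyclohexyl on this aromatic carbon brings no gain in this assay.

Going by these compounds, how a propyl chain would compare with ethyl at this position remains open. So does the effect of an amine or a carboxylic acid on this carbon.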